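Urea and Benzothiazole Variants Compared in a Cytotoxicity Test

The compounds below may be only part of what the source reports. "The series", "measured", "known", "first", "only" and "open" are said of these compounds alone.

Compound 1 `COc1ccc(-c2c(C)nc(NC(=O)NC3CCCCC3)c(C)c2C(OC(C)(C)C)C(=O)O)cc1` gives 19000 nM in an ADME assay on MT4 cells (Homo sapiens) for cytotoxicity, read by MTT assay; on this read-out higher numbers stand for lower toxicity in this test and lower numbers for higher toxicity in this test.
Compound 2 `Cc1ccc(-c2c(C)nc(Nc3nc4ccccc4s3)c(C)c2C(OC(C)(C)C)C(=O)O)cc1C` gives 6600 nM in this assay.
Compound 3 `Cc1ccc(-c2c(C)nc(NC(=O)Nc3ccccc3)c(C)c2C(OC(C)(C)C)C(=O)O)cc1C` gives 9900 nM in this assay.

Among the three measured numbers in this assay, compound 2 stands at the bottom: the gap to compound 3 is within the scatter, while compound 1 lies beyond it. Compound 4 `Cc1ccc(-c2c(C)nc(NC(=O)NCc3ccccc3)c(C)c2C(OC(C)(C)C)C(=O)O)cc1C` has not yet been measured. It differs from compound 2 in one place: benzylcarbamoyl in place of 1,3-benzothiazol-2-yl on a nitrogen on an aromatic ring. Among the measured compounds shown here, the only measured step that bears on this change is a 1.5-fold higher number from compound 2 to compound 3 (0.18 log units; within the scatter), where a carbamoyl group likewise replaced the 1,3-benzothiazol-2-yl group on the same nitrogen. That step stayed within the scatter, and compound 4 carries a benzylcarbamoyl group that is close in kind to the phenylcarbamoyl group of compound 3. The expected step is therefore a 1.4-fold higher number from compound 2 to compound 4 (0.13 log units; within the scatter) in this assay, which is no more than a small shift towards a higher number, if any beyond the scatter. Compound 4 is thus expected to give about 9000 nM in this assay, within a range from 4000 nM to 22000 nM.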

Compound 4, half-maximal cytotoxic concentration: 17000 nM
Compound 4: middle estimate off by 1.9-fold (0.28 log units), on the low side, and the stated range covers the measured number.
By their numbers in this assay, from the lowest: compounds 2, 3, 4 and 1 (each within the scatter of the next, the first and the last beyond it).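

Benzylcarbamoyl in place of 1,3-benzothiazol-2-yl on this nitrogen gives a 2.6-fold higher number from compound 2 to compound 4 (0.41 log units; beyond the scatter) in this assay, the first step at this position to go beyond the scatter, and the change of a 1.5-fold higher number from compound 2 to compound 3 (0.18 log units; within the scatter) had not done so. Benzyl in place of phenyl on the amide-type nitrogen gives a 1.7-fold higher number from compound 3 to compound 4 (0.23 log units; within the scatter) and so does not separate the two carbamoyl groups, which leaves the benzothiazole-to-urea change clear only for the benzyl member. Nothing at hand gives a reason for these steps.

The compounds shown leave open whether a longer chain such as phenethyl on the urea nitrogen would move the number further. Compound 1 differs from compound 4 in more than one place, so the effect of its cyclohexyl group alone also stays unread, as does that of an amine on the benzyl group.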